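The source may report more compounds than this note shows. Statements on the series, on what has been measured and on what is new or still open speak of the compounds shown alone.

Compound 1 `COC/C1=C/C[C@](C)(CCC=C(C)C)/C=C/[C@@H](OC(=O)C=C(C)C)[C@](C)(O)/C=C/C1=O` gives 3850 nM in a functional assay on SW480 cells (Homo sapiens) for antiproliferative activity, read by MTT assay, with a stated time of 48 h; on this read-out lower numbers stand for stronger inhibition and higher numbers for weaker inhibition.
Compound 2 `CC(C)=CCC[C@]1(C)/C=C/[C@@H](OC(=O)C=C(C)C)[C@](C)(O)/C=C/C(=O)/C(CN2CCN(C)CC2)=C\C1` gives 800 nM in this assay.

For the measured compounds named here, of these two numbers, compound 2 has the lower one; its only neighbour is compound 1, and the step of a 4.8-fold lower number from compound 1 to compound 2 (0.68 log units; beyond the scatter) lies beyond the scatter. Compound 3 `CC(C)=CCC[C@]1(C)/C=C/[C@@H](OC(=O)C=C(C)C)[C@](C)(O)/C=C/C(=O)/C(C(=O)N(C(C)C)C(C)C)=C\C1` has not yet been measured in this assay. It differs from compound 2 in one place: diisopropylcarbamoyl in place of (4-methylpiperazin-1-yl)methyl on a double-bonded ring carbon. Going by the values given here, the single measured step, from compound 1 to compound 2, exchanged a methoxy for a 4-methylpiperazin-1-yl on a saturated chain carbon bound to a double-bonded ring carbon and was modest. The present change removes that whole (4-methylpiperazin-1-yl)methyl group and sets a diisopropylcarbamoyl directly on the ring carbon, so that step gives only a loose guide. Compound 3 is therefore expected to give about 2000 nM, a step of a 2.5-fold higher number from compound 2 to compound 3 (0.40 log units; beyond the scatter) estimated with a wide range from 600 nM to 7000 nM.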

Compound 3, half-maximal inhibitory concentration: 16000 nM
Estimate against measurement, compound 3: 8.0-fold (0.90 log units) below, outside the stated range (above it).
By their numbers in this assay, from the lowest: compound 2; then compound 1; then compound 3.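

In this assay, for the compounds shown here, the earlier compounds showed only that a group on this double-bonded ring carbon can lower the number. Diisopropylcarbamoyl shows that a change here can also raise it, and by much more: it gives a 20-fold higher number from compound 2 to compound 3 (1.30 log units; beyond the scatter), and also a 4.2-fold higher number from compound 1 to compound 3 (0.62 log units; beyond the scatter), so it ranks behind both the (4-methylpiperazin-1-yl)methyl and the methoxymethyl groups. Nothing available explains the size of these steps.

Because the change replaces the whole group, the compounds shown cannot tell whether the carbonyl attached to the ring carbon or the two isopropyl groups accounts for the rise. A diisopropylaminomethyl group on this carbon would keep the isopropyl groups without the carbonyl, while a (4-methylpiperazin-1-yl)carbonyl group would keep the carbonyl without them.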